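This account rests on a few compounds, and the source may have more. Where it says the series, first, only, none or still open, it means among the compounds named here.

Measured compounds in a functional assay on Raji cells (Homo sapiens); on this read-out lower numbers stand for stronger inhibition and higher numbers for weaker inhibition:

Compound 1 `CCCCCCCCc1cn([C@H]2C[C@@H]3OP(=O)(O)OC[C@H]3O2)c(=O)[nH]c1=O`: compound 1 gives 184 ug/mL.
Compound 2 `CCCCCCc1cn([C@H]2C[C@H](O)[C@@H](CO)O2)c(=O)[nH]c1=O`: compound 2 gives 173 ug/mL.
Compound 3 `CCCCCCc1cn([C@H]2C[C@@H]3OP(=O)(O)OC[C@H]3O2)c(=O)[nH]c1=O`: for compound 3 the result is a limit of the assay, > 500 ug/mL.

Compound 1 and compound 3 share one core and differ by hydrogen in place of ethyl on a saturated chain carbon, six bonds along the chain from an aromatic carbon. That change gave an at least 2.7-fold higher number from compound 1 to compound 3 (0.43 log units; beyond the scatter), the step resting on (the limit of > 500 ug/mL in this assay, at which 1 of the 3 values shown sits). The values of compound 1 and compound 2 lie within the scatter of each other, and the difference between their two cores is not broken down here.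

The unmeasured compound 4 `CCCCc1cn([C@H]2C[C@H](O)[C@@H](CO)O2)c(=O)[nH]c1=O` is related to compound 2 by hydrogen in place of ethyl on a saturated chain carbon, four bonds along the chain from an aromatic carbon. This is the same kind of change as that from compound 1 to compound 3, though the place differs: six bonds along the chain from an aromatic carbon in the earlier pair, four bonds along the chain from an aromatic carbon here. On the strength of the earlier step of an at least 2.7-fold higher number from compound 1 to compound 3 (0.43 log units; beyond the scatter), a weakening of similar size is expected, giving a 2.3-fold higher number from compound 2 to compound 4 (0.36 log units; beyond the scatter). Compound 4 is accordingly estimated at 400 ug/mL, expected to fall between 200 ug/mL and 800 ug/mL, with a real chance that only a limit is reported.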

Compound 4, concentration for 50% inhibition: > 500 ug/mL
Compound 4: only a limit was reported; the forecaster's own chance of this, stated with the estimate: 45%; at least 1.2-fold (0.09 log units) between middle value and limit.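

In this assay compound 4 gives > 500 ug/mL, which is a limit of the assay and not a number. Putting hydrogen in place of ethyl on the core of compound 2, four bonds along the chain from an aromatic carbon, gave an at least 2.8-fold higher number from compound 2 to compound 4 (0.46 log units; beyond the scatter), so in these two pairs the change moves the number the same way, towards weaker inhibition, on both cores, and the sizes can be set side by side only as far as the limit allows: the same change on two cores in this assay, an at least 2.7-fold higher number (0.43 log units; beyond the scatter) from compound 1 to compound 3 and an at least 2.8-fold higher number (0.46 log units; beyond the scatter) from compound 2 to compound 4; the limit leaves it open whether they differ What this does not show is the true size of either step, so it cannot say whether the change costs the same on each core, as both steps end at one ceiling: the limit of > 500 ug/mL in this assay, at which 2 of the 4 values shown sit.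

The compounds shown leave open how a longer chain would read on either core. They also leave open whether an amine or a carboxylic acid at the end of the chain would bring the number down from that ceiling.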